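A few compounds are considered here, and "the series" means these few. Any claim that something is new, unique, unknown or untested is made for them only; others in the source may bear on it.

In a functional assay on the whole organism for antagonist activity, with Mus musculus as the target (a lower number here means that less compound is needed, a higher number that more compound is needed for the effect), compound 1 `CC(=O)N(C)CC#CCn1ccnc1` gives > 100 mg/kg, which is a limit of the assay and not a number. Compound 2 `COC(=O)N(C)CC#CCn1ccnc1` gives > 100 mg/kg, again a limit. Compound 3 `CCOC(=O)N(C)CC#CCN1CCCC1` gives > 100 mg/kg, also only a limit. Compound 4 `CCOC(=O)N(C)CC#CCn1ccnc1` differs from compound 3 by 1H-imidazol-1-yl in place of pyrrolidin-1-yl on a saturated chain carbon bound to a triple-bonded carbon. Going by the values given here, the one measured step, a step that the two limits leave unreadable from compound 1 to compound 2, changes a different group and offers no size to carry over. The 1H-imidazol-1-yl group already stands on compound 1 and compound 2, and both sit at the limit of > 100 mg/kg in this assay, at which 3 of the 3 values shown sit, so no gain in potency is expected from it. The expected step is a step that the limit leaves unreadable from compound 3 to compound 4, with no direction supported beyond the scatter. The estimated value for compound 4 is 150 mg/kg, with an expected range from 50 mg/kg to 400 mg/kg.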

Compound 4, dose for half-maximal effect: 97 mg/kg
Estimate against measurement, compound 4: 1.5-fold (0.19 log units) above; measured number inside the range.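

Going by these compounds alone, compound 4 is the only compound here with a readable number in this assay, while compound 1, compound 2 and compound 3 stay at a limit: the limit of > 100 mg/kg in this assay, at which 3 of the 4 values shown sit. Setting 1H-imidazol-1-yl in place of pyrrolidin-1-yl gives an at least 1.0-fold lower number from compound 3 to compound 4 (0.01 log units; that floor lies within the scatter), methyl in place of hydrogen gives an at least 1.0-fold lower number from compound 2 to compound 4 (0.01 log units; that floor lies within the scatter), and ethoxy in place of methyl gives an at least 1.0-fold lower number from compound 1 to compound 4 (0.01 log units; that floor lies within the scatter). Each of these is only a floor, so none shows a real gain.

On these data alone, the true size of all three steps stays open. So does the effect of a piperidine ring or a dimethylamino group in place of 1H-imidazol-1-yl.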